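Two extra chlorines on a benzoyl of an inactive pyrrole

This account rests on a few compounds, and the source may have more. Where it says the series, first, only, none or still open, it means among the compounds named here.

Compound 1 `Nc1[nH]c(C(=O)c2ccccc2)c(-c2ccc(Cl)cc2Cl)c1C(=O)c1ccccc1` carries two benzoyl groups and a 2,4-dichlorophenyl on a shared core. In an assay for inhibition of Polyunsaturated fatty acid lipoxygenase ALOX15 (Homo sapiens), with a stated time of 10 min (a lower number here means a stronger inhibitor, a higher number a weaker inhibitor), compound 1 gives only a limit of > 100000 nM. Compound 2 `Nc1[nH]c(C(=O)c2ccccc2)c(-c2ccc(-c3ccccc3)cc2)c1C(=O)c1cccc(Cl)c1` likewise returns only a limit of > 100000 nM in this assay. Compound 3 `Nc1[nH]c(C(=O)c2ccccc2)c(-c2ccc(Cl)cc2)c1C(=O)c1cccc(Cl)c1` also reaches only the limit of > 100000 nM. Among the compounds with values here, the one step between neighbours, a step that the two limits leave unreadable from compound 2 to compound 3, is therefore unreadable, and the whole picture is summed up by the limit of > 100000 nM in this assay, at which 3 of the 3 values shown sit.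

Compound 4 `Nc1[nH]c(C(=O)c2ccccc2)c(-c2ccc(Cl)cc2Cl)c1C(=O)c1ccc(Cl)c(Cl)c1` differs from compound 1 by 3,4-dichlorophenyl in place of phenyl on a carbonyl carbon. Within the data shown here, no measured step touches this benzoyl position, so nothing in the data predicts a gain or a loss beyond the scatter. With every neighbour at the limit, compound 4 is expected to stay there too, so the step of a number no higher from compound 1 to compound 4 (the limit leaves the size open) is estimated as essentially flat. Compound 4 is estimated at 100000 nM, with a range from 30000 nM to 300000 nM.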

Compound 4, half-maximal inhibitory concentration: 12800 nM
For compound 4 the middle estimate is 7.8-fold (0.89 log units) above the measured one; the measured number lies below the stated range.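

Placing 3,4-dichlorophenyl in place of phenyl on a carbonyl carbon gives an at least 7.8-fold lower number from compound 1 to compound 4 (0.89 log units; beyond the scatter) in this assay, the only sign among these compounds that this position can move the read-out. As far as these compounds go, for compound 1 the value > 100000 nM is a limit and not a number, so the full size of this step stays open. Compound 4 is the one compound here with a true number, which sets it apart from the limit reached by all the others: the limit of > 100000 nM in this assay, at which 3 of the 4 values shown sit.

The two chlorines enter together, and compound 2 and compound 3, which carry one chlorine on a benzoyl, also differ from compound 4 elsewhere, so the share of each chlorine cannot be read. From the compounds shown here alone, how a methoxy group, an amine or a carboxylic acid on this benzoyl would fare also stays open.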